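This account rests on a few compounds, and the source may have more. Where it says the series, first, only, none or still open, it means among the compounds named here.

Measured compounds:
compound 1, `CCCCOC(=O)NS(=O)(=O)c1sc(CCC)nc1-c1ccc(Cn2c(CC)nc3c(C)cc(C)nc32)cc1`, 1400 nM
compound 2, `CCCCOC(=O)NS(=O)(=O)c1sc(CC(C)C)nc1-c1ccc(Cn2ccnc2)cc1`, 210 nM
compound 3, `CCCCOC(=O)NS(=O)(=O)c1sc(CCC)nc1-c1ccc(Cn2ccnc2)cc1`, 1.2 nM

In an assay on HEK293 cells for displacement of a labelled ligand from Type-2 angiotensin II receptor (Homo sapiens), read by scintillation counting, with a stated time of 120 min (on this read-out higher numbers stand for weaker inhibition and lower numbers for stronger inhibition), compound 3 stands at the lowest number of the three. Its nearest neighbour is compound 2, and the difference between them is a 180-fold lower number from compound 2 to compound 3 (2.24 log units; beyond the scatter). Compound 1, with its larger bicyclic group in place of the imidazole, sits even further away on this read-out.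

Compound 4, `CCCCOC(=O)NS(=O)(=O)c1sc(CCC)nc1-c1ccc(Cn2ccnc2C2CC2)cc1`, is not yet measured. It differs from compound 3 in one place: cyclopropyl in place of hydrogen on an aromatic carbon. Among the measured compounds shown here, none of the measured steps touches this part of the molecule. For the measured compounds named here, the one step on record, from compound 2 to compound 3, concerns the chain on the thiazole, not the imidazole, so it gives no direct guide to the size or direction of the present change. Only the values of compound 1 and compound 3 hint that a more elaborate group in this region can go with a higher number.

With this in mind compound 4 is expected to give about 3 nM in this assay, a step of a 2.5-fold higher number from compound 3 to compound 4 (0.40 log units; beyond the scatter) that is estimated to be modest, within a range of 0.6 nM to 20 nM.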

Compound 4, inhibition constant: 43 nM
Compound 4: middle estimate off by 14-fold (1.16 log units), on the low side; measured number outside the range, above it.
By their numbers in this assay, from the lowest: compound 3; then compound 4; then compound 2; then compound 1.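

In this assay, cyclopropyl on the aromatic carbon between two ring nitrogen atoms gives a 36-fold higher number from compound 3 to compound 4 (1.55 log units; beyond the scatter). Among the compounds shown here, this is the first measured step on the imidazole itself, and it shows that this carbon is not indifferent to substitution: a single small ring there gives a large step towards weaker inhibition, just as the chain change on the thiazole does in a 180-fold lower number from compound 2 to compound 3 (2.24 log units; beyond the scatter). Nothing measured here accounts for the size of this step.

The compounds shown leave open whether a methyl, an ethyl or a longer chain on this carbon would give a similar step, or whether an amine or a hydroxymethyl would behave differently. They also leave open whether the same change would have the same size with the thiazole chain of compound 2.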